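The compounds below may be only part of what the source reports. "The series", "measured", "known", "first", "only" and "open" are said of these compounds alone.

Measured compounds in a functional assay on CHO-K1 cells with Glucose-dependent insulinotropic receptor (Homo sapiens) as the target, read by a luciferase reporter, with a stated time of 5 h; a higher number here means a larger maximal response, a lower number a smaller maximal response:
compound 1 `CC(C)OC(=O)N1CCC(Oc2ncnc3c2CCN3c2ccc(C#N)cc2F)CC1`: 134%
compound 2 `CC(C)OC(=O)N1CCC(Oc2ncnc3c2CCN3c2ccc(-c3cccn3C)cc2F)CC1`: 44%
compound 3 `COC(=O)N1CCC(Oc2ncnc3c2CCN3c2ccc(S(C)(=O)=O)cc2F)CC1`: 119%

Compound 3 stands second highest of the three numbers. Its nearest neighbour is compound 1, which lies higher by a margin beyond the scatter; compound 2 lies far below it, also beyond the scatter. Compound 1 and compound 3 differ in two places, so their gap cannot be assigned to either one of them.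

Compound 4 `CC(C)COC(=O)N1CCC(Oc2ncnc3c2CCN3c2ccc(S(C)(=O)=O)cc2F)CC1` is the next member and is not yet measured. It differs from compound 3 by isopropyl in place of hydrogen on a saturated chain carbon bound to an oxygen next to a carbonyl group, leaving the aryl part with its methylsulfonyl and fluorine untouched.

Among the measured compounds shown here, the only single-change step measured so far is a number 90 percentage points lower from compound 1 to compound 2 (beyond the scatter); it concerns the substituent on the aromatic carbon, not the carbamate chain, and so does not bear on the present change. For the measured compounds named here, compound 1 and compound 2 both carry the isopropyl ester and compound 3 the methyl ester, but no pair isolates that difference. Going by the values given here, there is therefore no measured step from which a direction can be read; the working expectation is a step of no more than the scatter in this assay , that is no change at the digits printed from compound 3 to compound 4 (within the scatter).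

Compound 4 is accordingly estimated at 119%, within a range of 95% to 145%.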

Compound 4, largest response reached (reported as percent of maximum), in percent of the reference or control that the assay uses: 94%
Compound 4: middle estimate off by 25 percentage points, on the high side; measured number outside the range, below it.
By their numbers in this assay, from the lowest: compound 2; then compound 4; then compound 3; then compound 1.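

In this assay, among the compounds shown here, the carbamate chain now proves to matter on its own: with the aryl part and its methylsulfonyl and fluorine held fixed, isopropyl in place of hydrogen on a saturated chain carbon bound to an oxygen next to a carbonyl group gives a number 25 percentage points lower from compound 3 to compound 4 (beyond the scatter), the first measured step at this position. The change from methoxycarbonyl to isobutoxycarbonyl therefore lowers the maximal response without abolishing it, with compound 4 still reaching 94% in this assay. Nothing at hand offers an explanation for this step.

The compounds shown do not separate the effect of chain length from that of branching, and an ethyl carbamate, a straight butyl carbamate or an isopropyl carbamate on the same methylsulfonyl aryl part would address that question. Going by these compounds, it also remains open whether a step of this direction and size would recur on the nitrile-bearing aryl part of compound 1, where the chain is an isopropyl carbamate rather than a methyl or isobutyl one.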